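Stability in buffer: carbonate-oxymethyl ester in place of ethyl

The source may hold more compounds than are shown below. What is called first, only, known or untested is meant among the compounds shown, and "the series" means these compounds.

Compound 1 `CCOC(=O)C1=C(S[C@@H]2CN[C@H](C(=O)Nc3cccc(C(=O)O)c3)C2)[C@H](C)[C@@H]2[C@@H]([C@@H](C)O)C(=O)N12` carries the shared core as an ethyl ester with a free carboxylic acid on the anilide. In a physicochemical assay for metabolic stability, read by LC-MS, in phosphate buffer, with a stated time of 3 h, at pH 7.4, tested at 50 uM (a lower number here means that less of the compound is left, a higher number that more of the compound is left), compound 1 gives > 95%, which is a limit of the assay and not a number. Compound 2 `C[C@@H](O)[C@H]1C(=O)N2C(C(=O)OCc3oc(=O)oc3C(C)(C)C)=C(S[C@@H]3CN[C@H](C(=O)Nc4cccc(C(=O)OCc5oc(=O)oc5C(C)(C)C)c4)C3)[C@H](C)[C@H]12` is the corresponding bis-ester. In this assay compound 2 also gives > 95%, again a limit rather than a measured figure. Going by the values given here, both values shown therefore sit at the limit of > 95% in this assay, at which 2 of the 2 values shown sit, so no step between measured compounds is available and nothing about the direction of an ester change can be read from them.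

Compound 3 `CCOC(=O)OCOC(=O)C1=C(S[C@@H]2CN[C@H](C(=O)Nc3cccc(C(=O)O)c3)C2)[C@H](C)[C@@H]2[C@@H]([C@@H](C)O)C(=O)N12` is the next member to be measured in this assay. It differs from compound 1 by (ethoxycarbonyl)oxy in place of methyl on a saturated chain carbon bound to an oxygen next to a carbonyl group. Among the compounds with values here, as no measured step covers this difference, the expectation rests on the two limits alone. Compound 3 is expected to remain largely intact, with a step from compound 1 of a number at least 5 percentage points lower from compound 1 to compound 3 (that floor lies within the scatter) that may fall within the scatter or slightly beyond it. The estimate for compound 3 in this assay is 90%, ranging from 70% to 98%.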

Compound 3, percent of the compound remaining: > 95%
Compound 3: no number, only a limit; the forecaster's own chance of this, stated with the estimate: 45%; middle value at least 5 percentage points from the limit.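

Going by these compounds alone, no step from compound 1 to compound 3 can be read in this assay, as both compounds sit at a limit of the assay and not at a number: the limit of > 95% in this assay, at which 3 of the 3 values shown sit. The compounds shown leave open whether compound 1, compound 2 and compound 3 differ at all in this assay, and which ester on the shared core, if any, would leave less of the compound remaining.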